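Alkyl chain extension on the core: compound 3 outlook

A few compounds are considered here, and "the series" means these few. Any claim that something is new, unique, unknown or untested is made for them only; others in the source may bear on it.

Measured compounds:
compound 1 `Cc1nc2nc(-c3ccccc3)cc(C(F)(F)F)c2c(=O)n1Cc1cn(CCC(F)(F)C(F)(F)C(F)(F)C(F)(F)C(F)(F)C(F)(F)F)nn1` — > 200 ug/mL in a functional assay on U-937 cells (Homo sapiens) for cytotoxicity, read by MTT assay, with a stated time of 24 h; on this read-out higher numbers stand for weaker inhibition and lower numbers for stronger inhibition
compound 2 `Cc1nc2nc(-c3ccccc3)cc(C(F)(F)F)c2c(=O)n1Cc1cn(CCC(F)(F)C(F)(F)C(F)(F)C(F)(F)C(F)(F)C(F)(F)C(F)(F)C(F)(F)F)nn1` — 124 ug/mL in this assay

In this assay compound 1 gives > 200 ug/mL, which is a limit of the assay and not a number. Compound 2 gives 124 ug/mL in this assay. Within the data shown here, the only measured step is an at least 1.6-fold lower number from compound 1 to compound 2 (0.20 log units; that floor lies within the scatter), a lengthening of the perfluorinated chain on the triazole-bound side; its floor does not exceed the scatter, so the two compounds cannot be ordered. Compound 1 sits at the limit of > 200 ug/mL in this assay, at which 1 of the 2 values shown sits.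

Compound 3 is `CCCCCCc1nc2nc(-c3ccccc3)cc(C(F)(F)F)c2c(=O)n1Cc1cn(CCC(F)(F)C(F)(F)C(F)(F)C(F)(F)C(F)(F)C(F)(F)F)nn1`. It differs from compound 1 by pentyl in place of hydrogen on a saturated chain carbon bound to an aromatic carbon. Among the measured compounds shown here, no measured pair changes the group on the saturated chain carbon bound to an aromatic carbon; the step from compound 1 to compound 2 alters a different part of the molecule and so gives no direct guide. The expectation therefore rests on compound 1 alone, whose value is a limit, and on the general spread seen for compound 2.

For compound 3 a value near the range of compound 2 is estimated, with an at least 1.3-fold lower number from compound 1 to compound 3 (0.12 log units; that floor lies within the scatter) as the expected step, and the estimate is 150 ug/mL with a range from 60 ug/mL to 300 ug/mL.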

Compound 3, half-maximal inhibitory concentration: 7.56 ug/mL
The estimate for compound 3 lay 20-fold (1.30 log units) above the measured number; measured number outside the range, below it.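

In this assay, pentyl in place of hydrogen on a saturated chain carbon bound to an aromatic carbon gives an at least 26-fold lower number from compound 1 to compound 3 (1.42 log units; beyond the scatter). This is the first step in the series that lies beyond the scatter, and it sits in a different part of the molecule from the change to the perfluorinated chain, which left compound 1 and compound 2 unordered, so this place is now shown to respond strongly to the group it carries. The size of the step is a floor only, since the value of compound 1 is a limit of the assay and not a number: the limit of > 200 ug/mL in this assay, at which 1 of the 3 values shown sits.

The compounds shown hold only methyl and hexyl at this place, so it remains open how the number runs with propyl, with a longer chain such as decyl, or with an amine or a carboxylic acid in place of pentyl. Also open, going by these compounds, is whether the same change gives a step of similar size on compound 2, with its longer perfluorinated chain, and what lies behind the step in compound 3.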